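From compound 2 to compound 3 at the assay limit

This account rests on a few compounds, and the source may have more. Where it says the series, first, only, none or still open, it means among the compounds named here.

In a functional assay on U-251 cells (Homo sapiens) for antiproliferative activity, read by MTT assay, with a stated time of 48 h (a higher number here means a weaker inhibitor, a lower number a stronger inhibitor), compound 1 `COc1ccc(-c2nc3cccc(-c4cc(OC)c(OC)c(OC)c4)c3o2)cc1` gives > 25000 nM as a limit, not a number. Compound 2 `COc1cc(-c2cccc3nc(-c4cccc(C)c4)oc23)cc(OC)c1OC` gives > 25000 nM as a limit too. Both measured compounds therefore sit at the same point (the limit of > 25000 nM in this assay, at which 2 of the 2 values shown sit). For the measured compounds named here, the only measured step (a step that the two limits leave unreadable from compound 1 to compound 2) has no readable size. Compound 3 `COc1cc(-c2nc3cccc(-c4cc(OC)c(OC)c(OC)c4)c3o2)ccc1O` carries 4-hydroxy-3-methoxyphenyl in place of 3-methylphenyl (4-hydroxy-3-methoxyphenyl in place of 3-methylphenyl on an aromatic carbon) on the shared core. Only a small move towards stronger inhibition is expected (an at least 1.2-fold lower number from compound 2 to compound 3 (0.09 log units; that floor lies within the scatter)) in this assay, since the measured step offers no size to carry over. Compound 3 is estimated at 20000 nM with a range of 6000 nM to 50000 nM in this assay, and another limit is quite possible.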

Compound 3, half-maximal inhibitory concentration: 10300 nM
Estimate against measurement, compound 3: 1.9-fold (0.29 log units) above; measured number inside the range.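

In this assay, 4-hydroxy-3-methoxyphenyl in place of 3-methylphenyl, on the aromatic carbon next to the ring nitrogen and next to the ring oxygen, gives an at least 2.4-fold lower number from compound 2 to compound 3 (0.38 log units; beyond the scatter). In place of 4-methoxyphenyl, the same group gives an at least 2.4-fold lower number from compound 1 to compound 3 (0.38 log units; beyond the scatter). These are the first readable changes at this position, while the step between compound 1 and compound 2 cannot be read, and both new steps are only floors since compound 1 and compound 2 stand at a limit: the limit of > 25000 nM in this assay, at which 2 of the 3 values shown sit.

From the compounds shown here alone, how a 4-hydroxyphenyl, a 3-methoxyphenyl or an aminophenyl group would compare at this position stays open. The compounds shown therefore do not separate the hydroxyl from the methoxy within the new group.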